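The compounds below may be only part of what the source reports. "The series", "measured", "known", "first", "only" and "open" are said of these compounds alone.

Going by the values given here, compound 2 `C#CCN(CCCOc1ccc2ccc(=O)oc2c1)Cc1ccc(C(C)C)cc1` is one of only two compounds measured in an ADME assay on isolated protein for inhibition of Amine oxidase [flavin-containing] A (Homo sapiens), read by fluorescence and Amplex Red, with stated times of 15 min and 20 min; on this read-out lower numbers stand for stronger inhibition and higher numbers for weaker inhibition; compound 2 gives 77400 nM, the lower of the two numbers. Compound 1 `C#CCN(CCCOc1ccc2ccc(=O)oc2c1)Cc1ccc(C)cc1` gives 116000 nM. Among the compounds with values here, the single measured step, a 1.5-fold lower number from compound 1 to compound 2 (0.18 log units; within the scatter), stays within the scatter. Compound 3 `C#CCN(CCCOc1ccc2ccc(=O)oc2c1)Cc1cccc(F)c1` differs from compound 2 by 3-fluorophenyl in place of 4-isopropylphenyl on a saturated chain carbon bound to an amine nitrogen. Within the data shown here, no measured step replaces the whole ring group at the same place, so the one known step offers only weak guidance, and it showed no change beyond the scatter. Compound 3 is therefore expected near compound 2, at 100000 nM with a range of 40000 nM to 250000 nM, an expected step of a 1.3-fold higher number from compound 2 to compound 3 (0.11 log units; within the scatter).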

Compound 3, half-maximal inhibitory concentration: 29300 nM
Estimate against measurement, compound 3: 3.4-fold (0.53 log units) above, outside the stated range (below it).
By their numbers in this assay, from the lowest: compound 3; then compounds 2 and 1 (each within the scatter of the next).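

The ring group on the saturated chain carbon bound to an amine nitrogen does affect inhibition: 3-fluorophenyl in place of 4-isopropylphenyl gives a clear gain (a 2.6-fold lower number from compound 2 to compound 3 (0.42 log units; beyond the scatter)). 3-Fluorophenyl in place of 4-methylphenyl points the same way (a 4.0-fold lower number from compound 1 to compound 3 (0.60 log units; beyond the scatter)), whereas the methyl-to-isopropyl step stayed within the scatter. Nothing measured here gives a reason for this gain.

Each step changes both the ring substituent and its ring position, leaving the contributions of fluorine and of its position unseparated. Plain phenyl, 4-fluorophenyl and 3-chlorophenyl would each test one of these open questions.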